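The source may report more compounds than this note shows. Statements on the series, on what has been measured and on what is new or still open speak of the compounds shown alone.

Working notes on the series in an ADME assay on HeLa cells (Homo sapiens) for cytotoxicity, read by ATP content, with a stated time of 3 days; on this read-out lower numbers stand for higher toxicity in this test and higher numbers for lower toxicity in this test.

Three compounds share one core and differ only in the group on an aromatic nitrogen of the fused five-membered ring. Compound 1 `N#CCCCn1c(Cn2c(=O)n(-c3ccncc3F)c3ccncc32)cc2cc(Cl)ccc21` carries 3-fluoropyridin-4-yl there, compound 2 `N#CCCCn1c(Cn2c(=O)n(C3CC3)c3ccncc32)cc2cc(Cl)ccc21` cyclopropyl, compound 3 `Cc1ccc(-n2c(=O)n(Cc3cc4cc(Cl)ccc4n3CCCC#N)c3cnccc32)cc1` 4-methylphenyl. In this assay compound 1 gives > 50000 nM, which is a limit of the assay and not a number. In this assay compound 2 gives > 50000 nM, again a limit. In this assay compound 3 gives > 50000 nM, also a limit. Within the data shown here, compound 3 thus stands where every value so far sits (the limit of > 50000 nM in this assay, at which 3 of the 3 values shown sit). The measured steps a step that the two limits leave unreadable from compound 1 to compound 2, a step that the two limits leave unreadable from compound 1 to compound 3 and a step that the two limits leave unreadable from compound 2 to compound 3 are unreadable for that reason.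

Compound 4 `COc1ccc(-n2c(=O)n(Cc3cc4cc(Cl)ccc4n3CCCC#N)c3cnccc32)c(F)c1` differs from compound 3 by 2-fluoro-4-methoxyphenyl in place of 4-methylphenyl on an aromatic nitrogen. Among the measured compounds shown here, no measured step gives a size for a change of this kind; three different groups on this nitrogen all left the value at the limit (the limit of > 50000 nM in this assay, at which 3 of the 3 values shown sit). The expected step is therefore a number no higher from compound 3 to compound 4 (the limit leaves the size open), none beyond the scatter. Compound 4 is estimated at 50000 nM, range 20000 nM to 100000 nM, most likely again reported only as a limit.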

Compound 4, half-maximal cytotoxic concentration: > 50000 nM
Compound 4: no number, only a limit; the forecaster's own chance of this, stated with the estimate: 85%; the middle value lies on the limit itself.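

No step to compound 4 from compound 1, compound 2 or compound 3 can be read, since all four compounds give only a limit and not a number: the limit of > 50000 nM in this assay, at which 4 of the 4 values shown sit.

The compounds shown leave open what number any of them would give, and whether any group on this nitrogen changes the value at all.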